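Chloro substitution on the benzoyl group of tetrahydroquinoline anilides

The compounds below may be only part of what the source reports. "The series", "measured", "known", "first", "only" and "open" are said of these compounds alone.

Compound 1 `O=C(Nc1ccccc1C(F)(F)F)C1CCc2ccccc2N1C(=O)c1ccccc1`: 6500 nM in a functional assay on HCT-15 cells (Homo sapiens) for cytotoxicity, read by sulforhodamine B assay, with a stated time of 72 h; on this read-out higher numbers stand for weaker inhibition of growth and lower numbers for stronger inhibition of growth
Compound 2 `O=C(Nc1ccccc1C(F)(F)F)C1CCc2ccccc2N1C(=O)c1ccc(Cl)cc1`: 839 nM in this assay
Compound 3 `O=C(Nc1cc(C(F)(F)F)cc(C(F)(F)F)c1)C1CCc2ccccc2N1C(=O)c1ccccc1`: 3540 nM in this assay

The series also contains compound 4 `O=C(Nc1cc(C(F)(F)F)cc(C(F)(F)F)c1)C1CCc2ccccc2N1C(=O)c1cccc(Cl)c1`, which has not yet been measured in this assay. Among the compounds with values here, the only measured step with a single change is a 7.7-fold lower number from compound 1 to compound 2 (0.89 log units; beyond the scatter), brought about by chloro in place of hydrogen on an aromatic carbon. Compound 3 and compound 1 share the amide-bearing core but carry different anilide groups; the difference between the two cores is not broken down here. Their values in this assay lie within the usual scatter of each other.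

Compound 4 arises from compound 3 by chloro in place of hydrogen on an aromatic carbon. This is the same kind of change as that from compound 1 to compound 2, but it is not the same: there the chloro stands para to a large group, here it stands meta to a large group. Because the earlier step gave a 7.7-fold lower number from compound 1 to compound 2 (0.89 log units; beyond the scatter), a step in the same direction is expected for compound 4, but on another core and with the chloro in a different place it is estimated at a more modest a 3.0-fold lower number from compound 3 to compound 4 (0.47 log units; beyond the scatter). Compound 4 is therefore expected to reach about 1200 nM in this assay, most likely between 400 nM and 3500 nM.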

Compound 4, concentration for 50% growth inhibition: 625 nM
Beside the measured number, compound 4's estimate is 1.9-fold (0.28 log units) above it; the measured number falls inside the stated range.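

In this assay, chloro in place of hydrogen on the benzoyl ring again gives a lower number, a 5.7-fold lower number from compound 3 to compound 4 (0.75 log units; beyond the scatter), and this step matches the earlier one within the scatter: the same change on two cores in this assay, a 7.7-fold lower number (0.89 log units; beyond the scatter) from compound 1 to compound 2 and a 5.7-fold lower number (0.75 log units; beyond the scatter) from compound 3 to compound 4, 1.4-fold (0.14 log units) apart, within the scatter of two such steps. The change therefore carries over between the two cores shown, with a step of similar size on each. This does not show that the core and the place of the chloro are without influence, since the two steps differ in both at once and each rests on a single pair of compounds, so any separate contributions of core and position cannot be told apart.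

The compounds shown leave open whether the 3-chlorophenyl group would give a step of the same size on the core of compound 1, and whether the chloro would do so in the other place on the core of compound 3. They also leave open whether another group on the benzoyl ring, such as a methoxy group, a fluoro group or an amine, would give a step like these.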